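Swapping a Pyridine for Cyclohexane on an Alkyne Arm

The compounds below may be only part of what the source reports. "The series", "measured", "known", "first", "only" and "open" are said of these compounds alone.

Compound 2 `CNC(=O)[C@@]12C[C@@H]1[C@@H](n1cnc3c(NC)nc(C#Cc4cccnc4)nc31)[C@H](O)[C@@H]2O` and compound 1 `CNC(=O)[C@@]12C[C@@H]1[C@@H](n1cnc3c(NC)nc(C#Cc4ccc(OC)cc4)nc31)[C@H](O)[C@@H]2O` share one core and differ only in the group attached to the triple-bonded carbon. In an assay on CHO cells for displacement of a labelled ligand from adenosine receptor A1 (Homo sapiens), read by scintillation counting, with a stated time of 60 min, tested at 10 uM (a higher number here means more inhibition at the concentration tested (going by the name of the read-out), a lower number less inhibition), compound 1 gives 10%, and compound 2 gives 16%. Going by the values given here, the only measured step, a number 6 percentage points higher from compound 1 to compound 2 (within the scatter), concerns an exchange of one aromatic group for another and falls within the scatter, so the two numbers cannot be told apart on these data. Compound 3 `CNC(=O)[C@@]12C[C@@H]1[C@@H](n1cnc3c(NC)nc(C#CC4CCCCC4)nc31)[C@H](O)[C@@H]2O` differs from compound 2 in a single place: cyclohexyl in place of pyridin-3-yl on a triple-bonded carbon. Among the compounds with values here, no measured step covers a change of this kind. Within the data shown here, both measured groups gave low inhibition and the one step between them was small, so compound 3 is expected to remain near them, and the expected step of a number 1 percentage points lower from compound 2 to compound 3 (within the scatter) is none beyond the scatter. The estimate for compound 3 in this assay is 15%, between 0% and 35%.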

Compound 3, a percentage reported as inhibition, at one concentration (the size of the read-out at that concentration, not a potency): 15%
The estimate for compound 3 equals the measured number at the digits printed, within the range that was stated.
By their numbers in this assay, from the lowest: compounds 1, 3 and 2 (each within the scatter of the next).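

In this assay, a ring of carbon only that is not aromatic can now be set against both aromatic groups: cyclohexyl in place of pyridin-3-yl gives a number 1 percentage points lower from compound 2 to compound 3 (within the scatter) and cyclohexyl in place of 4-methoxyphenyl gives a number 5 percentage points higher from compound 1 to compound 3 (within the scatter) on the same triple-bonded carbon. At this position, across these three compounds, neither an aromatic ring nor the ring nitrogen of pyridin-3-yl separates the numbers, so the three cannot be told apart at the single concentration tested. Nothing available here explains why such different rings read alike.

Still open, as far as these compounds go, is whether a group of another kind on the triple-bonded carbon, such as an amine or a carboxylic acid at the end of a longer chain, would move the number beyond the scatter. Also open, from the compounds shown here alone, is whether a smaller group there, such as methyl, would read like these three rings.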